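This account rests on a few compounds, and the source may have more. Where it says the series, first, only, none or still open, it means among the compounds named here.

Measured so far in an ADME assay on HepG2 cells (Homo sapiens) for cytotoxicity, read by MTT assay, with a stated time of 72 h; on this read-out lower numbers stand for higher toxicity in this test and higher numbers for lower toxicity in this test:
compound 1 `COc1ccc(-c2cc(Cl)cn3c([N+](=O)[O-])c(CS(=O)(=O)c4ccccc4)nc23)cc1`: > 3900 nM, a limit
compound 2 `O=[N+]([O-])c1c(CS(=O)(=O)c2ccccc2)nc2c(-c3ccc(CO)cc3)cc(Cl)cn12`: 13100 nM
compound 3 `O=[N+]([O-])c1c(CS(=O)(=O)c2ccccc2)nc2c(-c3ccc(F)cc3)cc(Cl)cn12`: > 15600 nM, a limit

Compound 3 has no exact number and is known only as a limit of > 15600 nM. Among the measured compounds shown here, compound 1 is the only other compound known just as a limit.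

Compound 4 `O=[N+]([O-])c1c(CS(=O)(=O)c2ccccc2)nc2c(-c3cccnc3)cc(Cl)cn12` differs from compound 3 by having pyridin-3-yl in place of 4-fluorophenyl on an aromatic carbon. For the measured compounds named here, no measured step makes this same exchange, though all three alter a group at this kind of aromatic carbon. Going by the values given here, the only step with any readable size is an at least 1.1-fold higher number from compound 2 to compound 3 (0.07 log units; that floor lies within the scatter). The other two give no size: a step that the limit leaves unreadable from compound 1 to compound 2, and a step that the two limits leave unreadable from compound 1 to compound 3.

Among the compounds with values here, with compound 2 at 13100 nM as the only exact value, no step beyond the scatter is expected in this assay, in either direction. The estimated step is a step that the limit leaves unreadable from compound 3 to compound 4. Compound 4 is expected at 20000 nM, with an estimated range from 8000 nM to 60000 nM.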

Compound 4, half-maximal cytotoxic concentration: > 31300 nM
Compound 4 ended at the assay's limit (the forecaster's own chance of this, stated with the estimate: 45%); middle value at least 1.5-fold (0.19 log units) from the limit.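

In this assay, the exchange to pyridin-3-yl at this aromatic carbon gives the only step beyond the scatter among the compounds shown, and it shows that a ring with a hetero atom is tolerated here: an at least 2.3-fold higher number from compound 2 to compound 4 (0.37 log units; beyond the scatter). Compound 4 is known only as a limit: the limit of > 31300 nM in this assay, at which 1 of the 4 values shown sits. The steps from compound 3 and from compound 1 to compound 4 cannot be read, as each joins two limits, so pyridin-3-yl cannot be ranked against 4-fluorophenyl or 4-methoxyphenyl.

The compounds shown leave open where the true values of compound 3 and compound 4 lie. They also leave open whether a phenyl ring carrying an amine or a carboxylic acid at this aromatic carbon would give a number as high as pyridin-3-yl does.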